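Three Aryl Variants and an Untested Aminophenyl Analogue

A few compounds are considered here, and "the series" means these few. Any claim that something is new, unique, unknown or untested is made for them only; others in the source may bear on it.

Compound 1 `COc1cc(-c2cc(-c3ccc(Cl)cc3)nc(-c3ccccc3)n2)cc(OC)c1OC` gives 7980 nM
Compound 2 `COc1cc(-c2cc(-c3ccc(Br)cc3)nc(-c3ccccc3)n2)cc(OC)c1OC` gives 4320 nM
Compound 3 `COc1cc(-c2cc(-c3ccc(O)cc3O)nc(-c3ccccc3)n2)cc(OC)c1OC` gives 5890 nM

These values come from a functional assay on HCT-116 cells (Homo sapiens) for inhibition, read by MTT assay, with a stated time of 48 h (a higher number here means a weaker inhibitor, a lower number a stronger inhibitor), and the three compounds differ in one place only. On these numbers compound 3 is not separated from the other two, with a 1.4-fold lower number from compound 1 to compound 3 (0.13 log units; within the scatter) and a 1.4-fold higher number from compound 2 to compound 3 (0.13 log units; within the scatter) as the steps that reach it. The remaining pair shows the same picture, with a 1.8-fold lower number from compound 1 to compound 2 (0.27 log units; within the scatter) as its step.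

The next compound is compound 4 `COc1cc(-c2cc(-c3ccc(N)cc3)nc(-c3ccccc3)n2)cc(OC)c1OC` and it carries 4-aminophenyl in place of 2,4-dihydroxyphenyl on an aromatic carbon at the same place that varies in the other three. Among the compounds with values here, none of the measured compounds carries 4-aminophenyl, so no measured step shows this group directly. All three measured steps bear on the change. They exchange the group at that place, and a 1.4-fold higher number from compound 2 to compound 3 (0.13 log units; within the scatter) is as small as a 1.4-fold lower number from compound 1 to compound 3 (0.13 log units; within the scatter) in size, while the largest of them is a 1.8-fold lower number from compound 1 to compound 2 (0.27 log units; within the scatter) and even that stays within the scatter.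

No shift beyond the scatter is therefore expected in either direction in this assay for this exchange. The estimated step is a 1.1-fold lower number from compound 3 to compound 4 (0.03 log units; within the scatter) and it would count as no real change. For compound 4 the estimated value is 5500 nM with an expected range from 2500 nM to 11000 nM as its bounds.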

Compound 4, half-maximal inhibitory concentration: 12300 nM
Compound 4: middle estimate off by 2.2-fold (0.35 log units), on the low side, outside the stated range (above it).
By their numbers in this assay, from the lowest: compounds 2, 3, 1 and 4 (each within the scatter of the next, the first and the last beyond it).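

In this assay this position proves able to register an exchange: the earlier swaps among 4-chlorophenyl, 4-bromophenyl and 2,4-dihydroxyphenyl all stayed within the scatter, whereas 4-aminophenyl gives a modest loss against two of them, with a 2.1-fold higher number from compound 3 to compound 4 (0.32 log units; beyond the scatter) and with a 2.8-fold higher number from compound 2 to compound 4 (0.45 log units; beyond the scatter) when amino takes the place of bromo. The loss is not general, since amino in place of chloro gives a 1.5-fold higher number from compound 1 to compound 4 (0.19 log units; within the scatter) and so stays within the scatter, which makes compound 1 the exception to any reading of compound 4 as weaker than all the others. Nothing available here explains why the amino group separates from compound 2 and compound 3 but not from compound 1.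

The compounds shown leave open whether the free amino group itself drives this modest shift, a question that a dimethylamino group, an acetamide or a carboxylic acid on the same phenyl ring would help to settle. They also leave open whether the same order would hold on any cell line other than the one used here.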